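The source may report more compounds than this note shows. Statements on the series, on what has been measured and on what is new or still open speak of the compounds shown alone.

Of the compounds shown here, three sharing one core have been tested in a functional assay on PC-3 cells (Homo sapiens) for antiproliferative activity, read by MTT assay; on this read-out lower numbers stand for stronger inhibition and higher numbers for weaker inhibition. Compound 1 `Cn1c(=O)c(=O)n(C2CCCC2)c2nc(N/N=C/c3ccccc3)ncc21` gives 48200 nM, compound 2 `Cc1cccc(/C=N/Nc2ncc3c(n2)n(C2CCCC2)c(=O)c(=O)n3C)c1` gives 53600 nM, and compound 3 `Cn1c(=O)c(=O)n(C2CCCC2)c2nc(N/N=C/c3cccc(Cl)c3Cl)ncc21` gives 17200 nM. Compound 2 sits close to compound 1, with only a 1.1-fold higher number from compound 1 to compound 2 (0.05 log units; within the scatter), while the gap shown by a 3.1-fold lower number from compound 2 to compound 3 (0.49 log units; beyond the scatter) is clearly larger. Compound 4 `Cn1c(=O)c(=O)n(C2CCCC2)c2nc(N/N=C/c3ccc(F)cc3Br)ncc21` has not been measured; it differs from compound 2 by 2-bromo-4-fluorophenyl in place of 3-methylphenyl on a carbon with a double bond to nitrogen. The step from compound 2 to compound 3 bears most on this change, since both replace a carbon-only phenyl group with a halogen-bearing one, and a 2.8-fold lower number from compound 1 to compound 3 (0.45 log units; beyond the scatter) points the same way. A modest lowering is therefore expected, roughly a 2.1-fold lower number from compound 2 to compound 4 (0.33 log units; beyond the scatter), giving compound 4 an estimated 25000 nM within a range of 10000 nM to 60000 nM.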

Compound 4, half-maximal inhibitory concentration: 9250 nM
Beside the measured number, compound 4's estimate is 2.7-fold (0.43 log units) above it; measured number below the stated range.
By their numbers in this assay, from the lowest: compounds 4 and 3 (each within the scatter of the next); then compounds 1 and 2 (each within the scatter of the next).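

On the carbon with a double bond to nitrogen, 2-bromo-4-fluorophenyl gives a clear lowering against both carbon-only groups (a 5.8-fold lower number from compound 2 to compound 4 (0.76 log units; beyond the scatter); a 5.2-fold lower number from compound 1 to compound 4 (0.72 log units; beyond the scatter)). Here, both halogen-bearing phenyl groups give lower numbers than phenyl and 3-methylphenyl, and no compound shown goes against this. Replacing 2,3-dichlorophenyl with 2-bromo-4-fluorophenyl does not separate them (a 1.9-fold lower number from compound 3 to compound 4 (0.27 log units; within the scatter)), so the two halogen patterns cannot be told apart. From the compounds shown here alone, whether a phenyl group bearing an amine or a carboxylic acid would fit this pattern remains open. Nothing shown accounts for the lowering.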